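The source may hold more compounds than are shown below. What is called first, only, known or untested is meant among the compounds shown, and "the series" means these compounds.

Compound 1 `c1cncc(N2CC[C@@H]3CN[C@@H]3C2)c1` and compound 2 `N#Cc1cncc(N2CC[C@@H]3CN[C@@H]3C2)c1` are built on the same core. In a functional assay on HEK293 cells for agonist activity at Neuronal acetylcholine receptor; alpha3/beta4 (Homo sapiens), read by FLIPR (a lower number here means that less compound is needed, a higher number that more compound is needed for the effect), compound 1 gives 260 nM and compound 2 gives 490 nM. The change between them, (cyano in place of hydrogen on an aromatic carbon), produced a 1.9-fold higher number from compound 1 to compound 2 (0.28 log units; within the scatter). Compound 3 `c1cncc(N2C[C@@H]3CCNC[C@@H]32)c1` has a different core; the difference between the two cores is not broken down here. In this assay compound 3 gives 1700 nM, the highest number of the three. Compound 4 `N#Cc1cncc(N2C[C@@H]3CCNC[C@@H]32)c1` has not been measured yet; it carries the same change on the core of compound 3, (cyano in place of hydrogen on an aromatic carbon), with the place described in identical words. For the measured compounds named here, that single earlier step a 1.9-fold higher number from compound 1 to compound 2 (0.28 log units; within the scatter) is the only guide, so a similarly small shift seems likely. Compound 4 is therefore expected to show a step of a 1.9-fold higher number from compound 3 to compound 4 (0.27 log units; within the scatter). Compound 4 is estimated at 3200 nM, probably between 1600 nM and 7000 nM.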

Compound 4, half-maximal effective concentration: 2560 nM
Beside the measured number, compound 4's estimate is 1.3-fold (0.10 log units) above it, within the range that was stated.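

In this assay the swap of hydrogen for cyano gives a 1.5-fold higher number from compound 3 to compound 4 (0.18 log units; within the scatter) and so stays small on this second core too. The two cores respond alike to this change: the same change on two cores in this assay, a 1.9-fold higher number (0.28 log units; within the scatter) from compound 1 to compound 2 and a 1.5-fold higher number (0.18 log units; within the scatter) from compound 3 to compound 4, 1.3-fold (0.10 log units) apart, within the scatter of two such steps. This shows that a small step carried over from one core to the other, but with both steps within the scatter it does not show that the nitrile shifts the number at all, and two cores cannot speak for any further core in this series.

Still open, from the compounds shown here alone, is how other groups on this aromatic carbon would behave, such as an amine, a carboxylic acid or a longer chain. Also open, going by these compounds, is whether cyano on a different carbon of the ring would give a similar step.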